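Swapping the Aryl Group on a Piperazine: No Gain Expected

The source may hold more compounds than are shown below. What is called first, only, known or untested is meant among the compounds shown, and "the series" means these compounds.

Compound 3 `Nc1scc(CN2CCN(c3cccnc3)CC2)c1C(=O)c1ccc(Cl)cc1` was tested in an assay on CHO cells for displacement of a labelled ligand from adenosine receptor A1 (Homo sapiens), read by scintillation counting, with a stated time of 120 min, tested at 10 uM (a lower number here means less inhibition, a higher number more inhibition at the concentration tested (going by the name of the read-out)), and gives 0%. Compound 1 `Nc1scc(CN2CCN(c3ccc(Cl)cc3F)CC2)c1C(=O)c1ccc(Cl)cc1` gives 0% and compound 2 `COc1ccc(N2CCN(Cc3csc(N)c3C(=O)c3ccc(Cl)cc3)CC2)cc1` gives 0%, so compound 3 stands level with both. Compound 4 `Nc1scc(CN2CCN(c3ccccc3F)CC2)c1C(=O)c1ccc(Cl)cc1` differs from compound 3 in one place: 2-fluorophenyl in place of pyridin-3-yl on an amine nitrogen in a ring. Going by the values given here, three measured steps bear on this kind of exchange, each swapping the aromatic group on the ring nitrogen: no change at the digits printed from compound 1 to compound 2 (within the scatter), no change at the digits printed from compound 1 to compound 3 (within the scatter) and no change at the digits printed from compound 2 to compound 3 (within the scatter). None of them moved the read-out beyond the scatter, so no step beyond the scatter is expected here either, in either direction. The expected step is no change at the digits printed from compound 3 to compound 4 (within the scatter). Compound 4 is estimated at 0%, with a range from -10% to 10%.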

Compound 4, a percentage reported as inhibition, at one concentration (the size of the read-out at that concentration, not a potency): 4%
Compound 4: middle estimate off by 4 percentage points, on the low side, and the stated range covers the measured number.
By their numbers in this assay, from the lowest: compounds 1, 2, 3 and 4 (each within the scatter of the next).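

In this assay the 2-fluorophenyl group on the amine nitrogen in the ring reads like the aromatic groups before it, with a number 4 percentage points higher from compound 3 to compound 4 (within the scatter) and a number 4 percentage points higher from compound 2 to compound 4 (within the scatter). The smallest edit so far, hydrogen in place of chloro on an aromatic carbon, also stays within the scatter, with a number 4 percentage points higher from compound 1 to compound 4 (within the scatter). No measured evidence is available to explain these results.

All the compounds shown carry an aromatic ring on this nitrogen. As far as these compounds go, whether a non-aromatic group, such as a cyclohexyl ring or a short alkyl chain, would read any differently remains open.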